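The source may hold more compounds than are shown below. What is called first, only, known or untested is meant among the compounds shown, and "the series" means these compounds.

Measured so far in an in vitro functional assay on 1321-N1 cells for antagonist activity at transient receptor potential cation channel subfamily V member 1 (Homo sapiens), read by FLIPR and calcium flux; on this read-out lower numbers stand for stronger inhibition and higher numbers for weaker inhibition:
Compound 1 `CC(C)(C)c1ccc(NC(=O)c2ccc(-c3ccccn3)cc2)cc1` gives 42 nM.
Compound 2 `O=C(Nc1ccc(Cl)cc1)C1=CCN(c2ncccc2Cl)CC1` gives 33 nM.
Compound 3 `O=C(Nc1ccc(Cl)c(F)c1)C1=CCN(c2ncccc2Cl)CC1` gives 78 nM.

Compound 3 carries the highest of the three numbers. Going by the values given here, its nearest neighbour is compound 1, whose value lies within the scatter of it; the gap to compound 2 is wider, and the only single-point step among the measured compounds, a 2.4-fold higher number from compound 2 to compound 3 (0.37 log units; beyond the scatter), is that modest move beyond the scatter. Compound 4 `O=C(Nc1ccc(Cl)c(Cl)c1)C1=CCN(c2ncccc2Cl)CC1` differs from compound 3 by chloro in place of fluoro on an aromatic carbon. Among the compounds with values here, no measured step swaps one halogen for another on that aromatic carbon; the one step that touches it, hydrogen to fluoro, was modest. The expectation in this assay is therefore no step beyond the scatter, a 1.1-fold lower number from compound 3 to compound 4 (0.05 log units; within the scatter). The estimate for compound 4 is 70 nM, with a range of 25 nM to 200 nM.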

Compound 4, half-maximal inhibitory concentration: 124 nM
Compound 4: middle estimate off by 1.8-fold (0.25 log units), on the low side; the measured number falls inside the stated range.
By their numbers in this assay, from the lowest: compounds 2, 1, 3 and 4 (each within the scatter of the next, the first and the last beyond it).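

In this assay, chloro in place of fluoro on this aromatic carbon, ortho to a chloro group, gives a 1.6-fold higher number from compound 3 to compound 4 (0.20 log units; within the scatter) and so does not separate the two halogens. Set against hydrogen, chloro gives a 3.8-fold higher number from compound 2 to compound 4 (0.57 log units; beyond the scatter) and thus moves the number upward, as fluoro did. Nothing available explains either change.

The compounds shown leave open how a methyl, a methoxy or an amine would behave on this carbon. They also leave open whether any group there would give a lower number than hydrogen.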